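Nitrofuran to nitrothiophene swap in a thiourea series

The source may hold more compounds than are shown below. What is called first, only, known or untested is meant among the compounds shown, and "the series" means these compounds.

Measured so far:
- compound 1, `COc1ccc(NC(=S)Nc2nnc(-c3ccc([N+](=O)[O-])o3)s2)cc1`: 86000 nM
- compound 2, `O=[N+]([O-])c1ccc(-c2nnc(NC(=S)Nc3ccc(F)cc3)s2)o1`: 72500 nM

In an ADME assay on HEK293 cells (Homo sapiens) for cytotoxicity, read by MTT assay, with a stated time of 48 h (on this read-out higher numbers stand for weaker inhibition and lower numbers for stronger inhibition), compound 1 gives 86000 nM, the highest of the two numbers; compound 2, nearest to it, gives 72500 nM. Among the measured compounds shown here, the only step in hand, a 1.2-fold lower number from compound 1 to compound 2 (0.07 log units; within the scatter), concerns the substituent on the outer benzene ring and not the five-membered ring on the other side of the shared core.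

Compound 3, `COc1ccc(NC(=S)Nc2nnc(-c3ccc([N+](=O)[O-])s3)s2)cc1`, differs from compound 1 by 5-nitrothiophen-2-yl in place of 5-nitrofuran-2-yl on an aromatic carbon. For the measured compounds named here, no measured pair covers this exchange of one heteroatom within the nitro-bearing ring, so the expectation rests only on compound 1 itself. Without a step that bears on this change, no movement beyond the scatter is expected: a 1.1-fold lower number from compound 1 to compound 3 (0.03 log units; within the scatter).

For compound 3 the estimated value in this assay is 80000 nM, with a range from 30000 nM to 200000 nM.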

Compound 3, half-maximal inhibitory concentration: 68200 nM
The estimate for compound 3 lay 1.2-fold (0.07 log units) above the measured number; low and high end bracket the measured number.
By their numbers in this assay, from the lowest: compounds 3, 2 and 1 (each within the scatter of the next).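

In this assay, among the compounds shown here, replacing 5-nitrofuran-2-yl with 5-nitrothiophen-2-yl on the shared core gives a 1.3-fold lower number from compound 1 to compound 3 (0.10 log units; within the scatter) with the methoxy-bearing outer ring held fixed, the first reading of this position. Exchanging one heteroatom within the nitro-bearing ring therefore cannot be told from the scatter here, just as a 1.2-fold lower number from compound 1 to compound 2 (0.07 log units; within the scatter) could not on the outer benzene ring, so neither side of the core has yet shown a step beyond it. No supporting measurement is available to explain the size of this step.

Still open, on these data alone, is whether the same exchange reads alike with the fluoro substituent of compound 2 on the outer ring. As far as these compounds go, it is also open whether an amine or a carboxylic acid in place of the nitro group on the five-membered ring would move the number beyond the scatter.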